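The compounds below may be only part of what the source reports. "The series", "measured", "known", "first", "only" and "open" are said of these compounds alone.

Measured compounds:
compound 1, `O=C(Nc1cccc2cn[nH]c12)N1CCN(Cc2cccc(Oc3ccc(Cl)cc3)c2)CC1`: 1300 nM
compound 2, `O=C(Nc1noc2cnccc12)N1CCN(Cc2cccc(Oc3ccc(Cl)cc3)c2)CC1`: 0.5 nM
compound 3, `O=C(Nc1noc2ccncc12)N1CCN(Cc2cccc(Oc3ccc(Cl)cc3)c2)CC1`: 180 nM

All three share one core and differ only in the aromatic group on the amide-type nitrogen of the urea. In an assay on isolated protein for inhibition of Fatty-acid amide hydrolase 1 (Homo sapiens), with a stated time of 60 min (a lower number here means a stronger inhibitor, a higher number a weaker inhibitor), compound 3 gives 180 nM, the second highest of the three numbers: it sits nearer to compound 1, which gives 1300 nM, than to compound 2, which gives 0.5 nM.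

Compound 4, `O=C(Nc1ccn2ccnc2c1)N1CCN(Cc2cccc(Oc3ccc(Cl)cc3)c2)CC1`, has not yet been measured. Relative to compound 3 it carries a group of 9 heavy atoms (7 carbon, 2 nitrogen; one five-membered aromatic ring with 2 hetero atoms, one six-membered aromatic ring with 1 hetero atom) in place of a group of 9 heavy atoms (6 carbon, 2 nitrogen, 1 oxygen; one five-membered aromatic ring with 2 hetero atoms, one six-membered aromatic ring with 1 hetero atom), on an amide-type nitrogen.

Every measured step swaps this same nine-atom group, and the outcomes range widely: a 7.2-fold lower number from compound 1 to compound 3 (0.86 log units; beyond the scatter), a 360-fold higher number from compound 2 to compound 3 (2.56 log units; beyond the scatter) and a 2600-fold lower number from compound 1 to compound 2 (3.41 log units; beyond the scatter). The swap that leads to compound 4 resembles none of them exactly, since neither the group entering nor a ring system without oxygen in this position has been measured. The account therefore expects a step of uncertain direction, most likely modest but with a broad spread, given how far the three measured groups lie apart.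

For compound 4 the expected value in this assay is 400 nM, within 40 nM to 4000 nM, which would mean a 2.2-fold higher number from compound 3 to compound 4 (0.35 log units; beyond the scatter).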

Compound 4, half-maximal inhibitory concentration: 33 nM
Beside the measured number, compound 4's estimate is 12-fold (1.08 log units) above it; measured number outside the range, below it.
By their numbers in this assay, from the lowest: compound 2; then compound 4; then compound 3; then compound 1.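

In this assay the entering group, with 7 carbon and 2 nitrogen atoms, gives a 5.5-fold lower number from compound 3 to compound 4 (0.74 log units; beyond the scatter) and so shows that a group with no oxygen can stand on this amide-type nitrogen and still give a lower number than the oxygen-bearing group of compound 3. The nitrogen-only groups are also far apart, with a 39-fold lower number from compound 1 to compound 4 (1.60 log units; beyond the scatter) showing that the same heavy-atom composition does not fix the result here, while a 66-fold higher number from compound 2 to compound 4 (1.82 log units; beyond the scatter) leaves the other oxygen-bearing group with the lowest number of the four. Oxygen content therefore does not sort these compounds, since the two oxygen-bearing compounds fall on either side of compound 4, and nothing shown accounts for the differences among these groups.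

The compounds shown leave open whether a single ring on this nitrogen, such as phenyl or pyridyl, would keep any of this range, and how a methyl or a fluorine on the group of compound 4 would shift its number. They also leave open whether the order of these four groups would hold if the chlorine on the shared core were replaced by a methoxy group.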